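A Methylcyclopropyl Stereocentre Flipped on a Bicyclic Amide

A few compounds are considered here, and "the series" means these few. Any claim that something is new, unique, unknown or untested is made for them only; others in the source may bear on it.

Compound 1, `O=C(C1CCC1)N1CC2CC(C1)N2`, in an assay on SH-EP1 cells for displacement of a labelled ligand from Neuronal acetylcholine receptor; alpha4/beta2 (Homo sapiens), read by scintillation counting; a lower number here means a stronger inhibitor, a higher number a weaker inhibitor: 16 nM
Compound 2, `C[C@@H]1C[C@@H]1C(=O)N1CC2CC(C1)N2`, in this assay: 22 nM
Compound 3, `C[C@H]1C[C@H]1C(=O)N1CC2CC(C1)N2`, in this assay: 7 nM

Compound 3 stands lowest of the three numbers in this assay: its nearest neighbour is compound 1, from which it differs by a 2.3-fold lower number from compound 1 to compound 3 (0.36 log units; beyond the scatter), and its furthest is compound 2, from which it differs by a 3.1-fold lower number from compound 2 to compound 3 (0.50 log units; beyond the scatter). Between compound 1 and compound 2 the difference is only a 1.4-fold higher number from compound 1 to compound 2 (0.14 log units; within the scatter). Compound 4, `C[C@@H]1C[C@H]1C(=O)N1CC2CC(C1)N2`, is not yet measured. It differs from compound 3 as follows: the two compounds have the same atoms and bonds; at least one stereo element is drawn with a configuration in one of them and without one in the other: 1 of 4 stereo elements differ; a stereocentre at a saturated ring carbon is drawn S in compound 3 and R in compound 4.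

Within the data shown here, the step from compound 2 to compound 3 is the only one that bears on a change of configuration alone, and it was modest, with the fact that one of compounds 2 and 3 is drawn with a defined configuration and the other without, at the place where they differ as the one piece of evidence on it. Flipping a single stereocentre is expected to move the number by a comparable or smaller amount, most likely upward from compound 3. Compound 4 is therefore expected to give 14 nM, between 5 nM and 40 nM. That estimate corresponds to an expected step of a 2.0-fold higher number from compound 3 to compound 4 (0.30 log units; within the scatter).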

Compound 4, inhibition constant: 1 nM
The estimate for compound 4 lay 14-fold (1.15 log units) above the measured number, and the stated range ends above it.
By their numbers in this assay, from the lowest: compound 4; then compound 3; then compounds 1 and 2 (each within the scatter of the next).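

In this assay, the configuration of the 2-methylcyclopropyl group matters more than compounds 2 and 3 alone could show. Changing a single stereocentre gives a 7.0-fold lower number from compound 3 to compound 4 (0.85 log units; beyond the scatter), and changing the other gives a 22-fold lower number from compound 2 to compound 4 (1.34 log units; beyond the scatter). The exchange of cyclobutyl for 2-methylcyclopropyl, which could earlier be read only as a small step, reaches a 16-fold lower number from compound 1 to compound 4 (1.20 log units; beyond the scatter) in this configuration, leaving compound 4 the lowest of the four. The only structural difference behind the step from compound 3 is one of configuration: the fact that one of compounds 3 and 4 is drawn with a defined configuration and the other without, at the place where they differ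

The compounds shown leave open how the remaining arrangement of the two stereocentres on the 2-methylcyclopropyl group would read. They also leave open whether a 2-ethylcyclopropyl or a 2-fluorocyclopropyl group on the carbonyl carbon would keep the low number of compound 4.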